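A few compounds are considered here, and "the series" means these few. Any claim that something is new, unique, unknown or untested is made for them only; others in the source may bear on it.

Compound 1 `COc1cc(-c2nn(-c3cccc(NC(=O)Nc4ccc(Cl)c(Cl)c4)c3)cc2-c2ccncc2)ccc1Cl` is the reference point of this set. In a functional assay on PC-3 cells (Homo sapiens) for inhibition, read by sulforhodamine B assay, with a stated time of 48 h (a lower number here means a stronger inhibitor of growth, a higher number a weaker inhibitor of growth), compound 1 gives 2830 nM, the lowest of the two numbers recorded. Its nearest neighbour is compound 3 `O=C(Nc1cccc(-n2cc(-c3ccncc3)c(-c3ccc(Cl)c(O)c3)n2)c1)Nc1cc(C(F)(F)F)cc(C(F)(F)F)c1`, which in this assay gives 4370 nM; the gap between the two lies within the scatter, so no order can be read between them. Compound 2 `O=C(Nc1cccc(-n2cc(-c3ccncc3)c(-c3ccc(Cl)c(O)c3)n2)c1)Nc1ccc(Cl)c(Cl)c1` gives in this assay only a limit of the assay, > 32500 nM, as recorded in the limit of > 32500 nM in this assay, at which 1 of the 3 values shown sits. Among the measured compounds shown here, the one step linking measured compounds, an at least 11-fold higher number from compound 1 to compound 2 (1.06 log units; beyond the scatter), concerns a different part of the structure, the oxygen on an aromatic ring. Compound 4 `COc1cc(-c2nn(-c3cccc(NC(=O)c4ccccc4)c3)cc2-c2ccncc2)ccc1Cl` differs from compound 1 by phenyl in place of (3,4-dichlorophenyl)amino on a carbonyl carbon. For the measured compounds named here, no measured step touches this part of the molecule, so the measured steps do not bear directly on the change, and the step from compound 1 to compound 2 shows only that the series responds strongly to change elsewhere. The estimate is therefore broad: compound 4 is expected to give 8000 nM, within 2000 nM to 32500 nM. The expected step of a 2.8-fold higher number from compound 1 to compound 4 (0.45 log units; beyond the scatter) is toward a higher number.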

Compound 4, concentration for total growth inhibition: > 100000 nM
Compound 4: no number, only a limit; the forecaster's own chance of this, stated with the estimate: 20%; middle value at least 12-fold (1.09 log units) away from the limit.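

The step from the (3,4-dichlorophenyl)amino group to phenyl on the carbonyl carbon is an at least 35-fold higher number from compound 1 to compound 4 (1.54 log units; beyond the scatter), so growth inhibition in this assay also responds strongly at this position, which the earlier step did not touch. The earlier compounds had shown a strong response only at the oxygen on the aromatic ring, whereas compound 4 keeps the methyl on that oxygen and still loses inhibition. Compound 4 gives > 100000 nM in this assay, which is a limit and not a number, so the full size of the step stays unknown: the limit of > 100000 nM in this assay, at which 1 of the 4 values shown sits.

This change removes the nitrogen and both chlorines together, and the compounds shown do not separate these parts. Plain phenylamino or 3,4-dichlorophenyl on the same carbonyl carbon would be needed to tell them apart.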